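Arylidene oxindole glycosides: dimethylamino in place of methyl

This account rests on a few compounds, and the source may have more. Where it says the series, first, only, none or still open, it means among the compounds named here.

Values below are from a functional assay on A549 cells (Homo sapiens) for cytotoxicity, read by sulforhodamine B assay, with a stated time of 48 h; a higher number here means a weaker inhibitor, a lower number a stronger inhibitor.

Compound 1 `COc1ccc2c(c1)c(/C=N/O)cn2Cc1cn([C@@H]2O[C@H](COC(C)=O)[C@@H](OC(C)=O)[C@H](OC(C)=O)[C@H]2OC(C)=O)nn1`: > 200000 nM, which is a limit of the assay and not a number.
Compound 2 `CC(=O)OC[C@H]1O[C@@H](n2cc(CN3C(=O)/C(=C/c4ccc(C)cc4)c4ccccc43)nn2)[C@H](OC(C)=O)[C@@H](OC(C)=O)[C@@H]1OC(C)=O`: 16000 nM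
Compound 3 `CC(=O)OC[C@H]1O[C@@H](n2cc(CN3C(=O)/C(=C\c4ccc(C)cc4)c4ccccc43)nn2)[C@H](OC(C)=O)[C@@H](OC(C)=O)[C@@H]1OC(C)=O`: 16500 nM

Compound 2 stands at the lowest of the two numbers given in this assay, with compound 3 sitting within the scatter of it. Going by the values given here, the only measured step, a 1.0-fold higher number from compound 2 to compound 3 (0.01 log units; within the scatter), is within the scatter; the pair differs solely in the configuration as drawn (the fact that compounds 2 and 3 differ only in the configuration as drawn). The limit of compound 1 the limit of > 200000 nM in this assay, at which 1 of the 3 values shown sits, gives no usable number for comparison.

The unmeasured compound 4 `CC(=O)OC[C@H]1O[C@@H](n2cc(CN3C(=O)/C(=C/c4ccc(N(C)C)cc4)c4ccccc43)nn2)[C@H](OC(C)=O)[C@@H](OC(C)=O)[C@@H]1OC(C)=O` differs from compound 2 by dimethylamino in place of methyl on an aromatic carbon. Among the compounds with values here, no measured step touches a substituent on that six-membered ring, and the one step available concerns a different kind of change. No step beyond the scatter is therefore expected in this assay from compound 2 to compound 4; the expected step is a 1.1-fold lower number from compound 2 to compound 4 (0.06 log units; within the scatter). Compound 4 is estimated at 14000 nM, within a range of 4000 nM to 50000 nM.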

Compound 4, half-maximal inhibitory concentration: 19400 nM
Compound 4: the middle estimate sits 1.4-fold (0.14 log units) below what was measured; measured number inside the range.
By their numbers in this assay, from the lowest: compounds 2, 3 and 4 (each within the scatter of the next). At a limit, above all of these: compound 1.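

At this place on the six-membered aromatic ring, para to a large group, the step in this assay is a 1.2-fold higher number from compound 2 to compound 4 (0.08 log units; within the scatter). Going by these compounds alone, until now the only readable step concerned configuration as drawn, so this is the first reading of a substituent change, and 4-(dimethylamino)phenyl, with 3 heavy atoms and 1 hydrogen-bond acceptor in the group in place of the single carbon of methyl, does not separate from 4-methylphenyl in this pair. No measured property of either group bears on this result.

As far as these compounds go, whether a carboxylic acid or a fluorine at the same place would give a step beyond the scatter remains open. Also open, from the compounds shown here alone, is whether the double-bond partner of compound 4 would read alongside it, as compound 3 does alongside compound 2.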